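The source may hold more compounds than are shown below. What is called first, only, known or untested is meant among the compounds shown, and "the series" means these compounds.

Compound 1 `Cc1ccc(-c2nccn2C)cc1NC(=O)c1ccc(OCc2ccccn2)cc1` and compound 2 `Cc1ccc(-c2c(C)nn(C)c2C)cc1NC(=O)c1ccc(OCc2ccccn2)cc1` share one core and differ only in the group attached to one aromatic carbon. In an ADME assay on a cell-free system (plasma, Homo sapiens) for protein binding (a lower number here means a smaller unbound share, a higher number a larger unbound share of the compound), compound 1 gives 0.051 and compound 2 gives 0.018, which is a change of a 2.8-fold lower number from compound 1 to compound 2 (0.45 log units; beyond the scatter). Among the compounds with values here, compound 2 thus stands at the lower of the two measured numbers, with compound 1 as its sole and nearest neighbour. Compound 3 `Cc1ccc(-c2cccnc2)cc1NC(=O)c1ccc(OCc2ccccn2)cc1` has not been measured yet; it differs from compound 2 by pyridin-3-yl in place of 1,3,5-trimethyl-1H-pyrazol-4-yl on an aromatic carbon. Within the data shown here, the one measured step that bears on this change is the exchange at the same carbon, a 2.8-fold lower number from compound 1 to compound 2 (0.45 log units; beyond the scatter), where the number fell as the trimethylpyrazolyl entered. Taking that same group away again points back upward, so an increase of about that size, a 2.5-fold higher number from compound 2 to compound 3 (0.40 log units; beyond the scatter), is expected. Compound 3 is therefore estimated at 0.045, with a range from 0.02 to 0.1.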

Compound 3, unbound fraction: < 0.01
Compound 3 ended at the assay's limit; the forecaster's own chance of this, stated with the estimate: 5%; at least 4.5-fold (0.65 log units) between middle value and limit.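

Compound 3 gives < 0.01 in this assay, which is a limit of the assay and not a number: the limit of < 0.01 in this assay, at which 1 of the 3 values shown sits. Pyridin-3-yl in place of 1,3,5-trimethyl-1H-pyrazol-4-yl gives an at least 1.8-fold lower number from compound 2 to compound 3 (0.25 log units; that floor lies within the scatter), so losing that group does not lift the number back toward that of compound 1. Against 1-methyl-1H-imidazol-2-yl the same group gives an at least 5.1-fold lower number from compound 1 to compound 3 (0.70 log units; beyond the scatter), so among these three compounds 1-methyl-1H-imidazol-2-yl on this carbon goes with the largest unbound share, and the low number of compound 2 is not peculiar to the 1,3,5-trimethyl-1H-pyrazol-4-yl.

From the compounds shown here alone, how far compound 3 really lies past its limit stays unknown, so the order of compound 2 and compound 3 cannot be read. Also open, going by these compounds, is what a carboxylic acid or an amine on the same aromatic carbon would do to the unbound share.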